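A few compounds are considered here, and "the series" means these few. Any claim that something is new, unique, unknown or untested is made for them only; others in the source may bear on it.

The measured compounds:
Compound 1 `COc1cccc(OC)c1C(=O)Nc1nnc(-c2ccccc2)s1` gives 282 nM in a functional assay on the whole organism (integument) for inhibition, with Chilo suppressalis as the target, read by scintillation counting, with a stated time of 72 h, in the presence of a further agent that is not named here; a higher number here means a weaker inhibitor, a lower number a stronger inhibitor.
Compound 2 `COc1cccc(OC)c1C(=O)Nc1nnc(-c2ccc(C(C)C)cc2)s1` gives 182 nM in this assay.
Compound 3 `COc1cccc(OC)c1C(=O)Nc1nnc(-c2ccc(I)cc2)s1` gives 97.7 nM in this assay.

Compound 3 stands at the lowest of the three numbers, but only its gap to compound 1 is beyond the scatter: a 2.9-fold lower number from compound 1 to compound 3 (0.46 log units; beyond the scatter). Its gap to compound 2 is not: a 1.9-fold lower number from compound 2 to compound 3 (0.27 log units; within the scatter). The account now turns to compound 4 `CCOc1ccc(-c2nnc(NC(=O)c3c(OC)cccc3OC)s2)cc1`, which differs from compound 3 by ethoxy in place of iodo on an aromatic carbon. For the measured compounds named here, no measured pair shows this exact exchange. Going by the values given here, the steps that bear on it are the three substitutions at the same aromatic carbon: a 2.9-fold lower number from compound 1 to compound 3 (0.46 log units; beyond the scatter), a 1.5-fold lower number from compound 1 to compound 2 (0.19 log units; within the scatter) and a 1.9-fold lower number from compound 2 to compound 3 (0.27 log units; within the scatter). Only the entry of iodo moved the number beyond the scatter; isopropyl in the same place left the number within the scatter of compound 1. Ethoxy is a further substituent at that carbon, so a number between those of compound 3 and compound 1 is expected. The step expected from this exchange is a 1.6-fold higher number from compound 3 to compound 4 (0.21 log units; within the scatter), most likely within the scatter. The estimate for compound 4 in this assay is 160 nM, with a range from 70 nM to 400 nM.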

Compound 4, half-maximal inhibitory concentration: 95.5 nM
For compound 4 the middle estimate is 1.7-fold (0.22 log units) above the measured one, within the range that was stated.
By their numbers in this assay, from the lowest: compounds 4, 3, 2 and 1 (each within the scatter of the next, the first and the last beyond it).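

The exchange of iodo for ethoxy at this aromatic carbon leaves no difference that can be read in this assay (a 1.0-fold lower number from compound 3 to compound 4 (0.01 log units; within the scatter)), although iodo is one heavy atom with no hydrogen-bond acceptor and ethoxy is three heavy atoms with one. Ethoxy is also a second substituent, after iodo, whose step from hydrogen lies beyond the scatter (a 3.0-fold lower number from compound 1 to compound 4 (0.47 log units; beyond the scatter)). Its step from isopropyl stays within the scatter (a 1.9-fold lower number from compound 2 to compound 4 (0.28 log units; within the scatter)), so isopropyl cannot be separated from either ethoxy or iodo.

From the compounds shown here alone, how an amine, a carboxylic acid or a longer alkoxy chain such as butoxy would read at this carbon remains open. The data given here offer no explanation for the match between ethoxy and iodo.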